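Notes on the step from compound 2 to compound 3

This account rests on a few compounds, and the source may have more. Where it says the series, first, only, none or still open, it means among the compounds named here.

compound 1 `COc1cccc(NC(=O)c2nnn(CC3CCN(C(C)=O)CC3)c2N)c1` gives > 50100 nM as a limit
compound 2 `COc1cccc(NC(=O)c2nnn(Cc3cc(C)on3)c2N)c1` gives > 50100 nM as a limit

In a toxicity assay on Vero cells (Chlorocebus sabaeus) for inhibition (a higher number here means that more compound is needed for the effect, a lower number that less compound is needed), compound 2 gives > 50100 nM as a limit of the assay, not a number. For the measured compounds named here, the evidence so far is the limit of > 50100 nM in this assay, at which 2 of the 2 values shown sit, and nothing more.

Compound 3 `COc1cccc(NC(=O)c2nnn(Cc3ccc(SC)cc3)c2N)c1` carries a new group on the same chain carbon: 4-(methylsulfanyl)phenyl in place of 5-methyl-1,2-oxazol-3-yl on a saturated chain carbon bound to an aromatic nitrogen is the change from compound 2.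

Going by the values given here, the only measured step at this place is a step that the two limits leave unreadable from compound 1 to compound 2 and it offers no size to carry over. In this assay no step beyond the scatter is therefore expected, and no direction is favoured. The step expected is a number no higher from compound 2 to compound 3 (the limit leaves the size open) for now. Compound 3 is estimated at 50000 nM with an expected range of 20000 nM to 100000 nM and will probably report only a limit again.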

Compound 3, half-maximal effective concentration in the Vero assay: > 50100 nM
Compound 3: a limit, no number (the forecaster's own chance of this, stated with the estimate: 75%); middle value at least 1.0-fold (0.00 log units) away from the limit.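

In the Vero assay compound 3 gives > 50100 nM, which is a limit of the assay and not a number. Compound 1 and compound 2 also report only a limit in the Vero assay, so no step among these three compounds can be read. The compounds shown leave open whether the group on the saturated chain carbon changes the number in the Vero assay at all. In a physicochemical assay for solubility, read by nephelometry, at pH 7.4 (a higher number here means a more soluble compound, a lower number a less soluble compound), compound 2 gives 174000 nM. In the physicochemical assay compound 3 gives < 12000 nM, which is a limit of the assay and not a number.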